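Carboxy in place of fluoro on the pyridyl of compound 1

A few compounds are considered here, and "the series" means these few. Any claim that something is new, unique, unknown or untested is made for them only; others in the source may bear on it.

Compound 1 `Fc1ccc(Nc2cc3[nH]c(-c4cccc(C(F)(F)F)c4)nc3cn2)nc1` gives >= 50000 nM in a physicochemical assay for solubility, using the shake flask method, in simulated intestinal fluid, measured as kinetic solubility, with a stated time of 20 h, at pH 6.5; a higher number here means a more soluble compound, a lower number a less soluble compound; that value is a limit of the assay, not a number. Compound 2 `Fc1ccnc(Nc2cc3[nH]c(-c4ccc(F)c(F)c4)nc3cn2)c1` also returns >= 50000 nM in this assay, a limit. Compound 3 `Fc1ccc(Nc2cc3[nH]c(-c4ccc(F)c(C(F)(F)F)c4)nc3cn2)nc1` likewise shows >= 50000 nM, again a limit. Among the measured compounds shown here, the only single-change step among them, a step that the two limits leave unreadable from compound 1 to compound 3, cannot be read, since the limit of >= 50000 nM in this assay, at which 3 of the 3 values shown sit, holds all three values. Compound 4 `O=C(O)c1ccc(Nc2cc3[nH]c(-c4cccc(C(F)(F)F)c4)nc3cn2)nc1` differs from compound 1 by carboxy in place of fluoro on an aromatic carbon. For the measured compounds named here, no measured step bears on this change, and the series offers no readable size of step in this assay for comparison. Compound 4 is therefore expected to sit at the same limit, with the step of a number no higher from compound 1 to compound 4 (the limit leaves the size open) estimated as nothing readable. The estimate for compound 4 is 50000 nM, range 15000 nM to 50000 nM.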

Compound 4, solubility: 6000 nM
For compound 4 the middle estimate is 8.3-fold (0.92 log units) above the measured one; measured number below the stated range.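

In this assay, the change from 5-fluoropyridin-2-yl to 5-carboxypyridin-2-yl gives an at least 8.3-fold lower number from compound 1 to compound 4 (0.92 log units; beyond the scatter), so a change at this place, para to a large group, can be read. Among the compounds shown here, the step among the earlier compounds cannot be read. Compound 4 alone gives a number rather than a limit: the limit of >= 50000 nM in this assay, at which 3 of the 4 values shown sit.

Going by these compounds, the full size of the step stays open. So does whether an amide, a methyl ester or an amine at this place would also leave the limit, and how far the number would fall with each.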